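The compounds below may be only part of what the source reports. "The series", "measured", "known", "first", "only" and "open" are said of these compounds alone.

In an ADME assay on HEK293 cells (Homo sapiens) for cytotoxicity, read by MTT assay, with a stated time of 72 h (a lower number here means a stronger inhibitor, a higher number a weaker inhibitor), compound 1 `O=C(CN1CCN(C(=O)c2ccccc2)CC1)N1CCN(CCCc2c[nH]c3ccccc23)CC1` gives > 200000 nM which is a limit of the assay and not a number. Going by the values given here, compound 2 `O=C(CN1CCN(C(=O)c2ccc(Cl)cc2)CC1)N1CCN(CCCc2c[nH]c3ccccc23)CC1` gives 98200 nM as the only true number so far. Among the compounds with values here, the one measured step, chloro in place of hydrogen on an aromatic carbon, is an at least 2.0-fold lower number from compound 1 to compound 2 (0.30 log units; that floor lies within the scatter) and it touches the same carbon as the next change. On these data alone, the real size of that step stays open because of the limit of > 200000 nM in this assay, at which 1 of the 2 values shown sits, and little more can be read from it. Compound 3 `COc1ccc(C(=O)N2CCN(CC(=O)N3CCN(CCCc4c[nH]c5ccccc45)CC3)CC2)cc1` departs from compound 2 by methoxy in place of chloro on an aromatic carbon in the form of methoxy in place of chloro on an aromatic carbon, para to a large group. Within the data shown here, no measured step covers methoxy. Compound 2 at 98200 nM is therefore the anchor, and no step beyond the scatter is expected in this assay with at most a slight drift toward a higher number. The expected change is a 1.2-fold higher number from compound 2 to compound 3 (0.09 log units; within the scatter) as an estimate resting on that anchor. The estimate for compound 3 is 120000 nM with an expected range from 60000 nM to 200000 nM for this reading.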

Compound 3, half-maximal inhibitory concentration: 156000 nM
For compound 3 the middle estimate is 1.3-fold (0.11 log units) below the measured one; measured number inside the range.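

In this assay, the exchange on the aromatic carbon para to a large group gives a 1.6-fold higher number from compound 2 to compound 3 (0.20 log units; within the scatter), so replacing chloro with methoxy, which adds one hydrogen-bond acceptor and one heavy atom, does not separate these two compounds. Going by these compounds alone, this position now has two substituents with true numbers, where the earlier compounds offered only one, and the two lie within the scatter of each other. Compound 1 remains a limit of the assay and not a number, so an at least 1.2-fold lower number from compound 1 to compound 3 (0.10 log units; that floor lies within the scatter) gives only a floor, and the real size of the move from hydrogen to either substituent cannot be read: the limit of > 200000 nM in this assay, at which 1 of the 3 values shown sits.

Within the data shown here, whether any group at this position can move the number beyond the scatter remains open, since chloro and methoxy are the only two substituents with true numbers here. An amine or a carboxylic acid on the same carbon, or a longer chain such as ethoxy in place of methoxy, would show whether this insensitivity extends past the two groups shown.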